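A methoxy for a methyl: compound 3 to compound 4

This account rests on a few compounds, and the source may have more. Where it says the series, first, only, none or still open, it means among the compounds named here.

Compound 3 `Cc1ccc(-c2csc(N3N=C(c4ccc(C)s4)CC3c3ccc(F)cc3)n2)cc1` was tested in a functional assay on A549 cells (Homo sapiens) for antiproliferative activity, read by XTT assay, with a stated time of 24 h; a higher number here means a weaker inhibitor, a lower number a stronger inhibitor. In this assay compound 3 gives only a limit, > 500 ug/mL, not a number. That puts it at the limit of > 500 ug/mL in this assay, at which 2 of the 3 values shown sit. Compound 1 `Fc1ccc(C2CC(c3ccc(Cl)s3)=NN2c2nc(-c3ccccc3)cs2)cc1` likewise shows only a limit, > 500 ug/mL. Within the data shown here, compound 2 `Fc1ccc(C2CC(c3ccc(Cl)s3)=NN2c2nc(-c3ccc(Br)cc3)cs2)cc1` gives 62.5 ug/mL, and the one measured step, an at least 8.0-fold lower number from compound 1 to compound 2 (0.90 log units; beyond the scatter), concerns a different change. Compound 4 `COc1ccc(-c2csc(N3N=C(c4ccc(C)s4)CC3c3ccc(F)cc3)n2)cc1` differs from compound 3 by methoxy in place of methyl on an aromatic carbon. Among the measured compounds shown here, no measured step covers a methoxy in place of a methyl, so no direction can be read from the data. Compound 4 is therefore expected to stay near the limit, estimated at 400 ug/mL, within 100 ug/mL to 500 ug/mL, a step of an at least 1.2-fold lower number from compound 3 to compound 4 (0.09 log units; that floor lies within the scatter) that is expected rather than known.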

Compound 4, half-maximal inhibitory concentration: 184 ug/mL
Estimate against measurement, compound 4: 2.2-fold (0.34 log units) above; measured number inside the range.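

In this assay, the change from 4-methylphenyl to 4-methoxyphenyl gives a second measured step at this position: an at least 2.7-fold lower number from compound 3 to compound 4 (0.43 log units; beyond the scatter). Until now only a bromo had lowered the number here, so a methoxy now does this too, on a compound with a different group elsewhere. Compound 3 shows only a limit, so the true size of this step remains unknown: the limit of > 500 ug/mL in this assay, at which 2 of the 4 values shown sit.

The compounds shown leave open how an amine, a carboxylic acid or a longer chain such as ethoxy would behave at this position.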